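Aryl exchange on the ring amine in two related cores

A few compounds are considered here, and "the series" means these few. Any claim that something is new, unique, unknown or untested is made for them only; others in the source may bear on it.

In an assay on isolated protein for binding affinity to Adrenergic receptor alpha-1 (Rattus norvegicus), read by radioligand binding (a lower number here means a stronger inhibitor, a higher number a weaker inhibitor), compound 1 `O=C1C2CCCN2C(=O)N1CN1CCN(c2cccc(Cl)c2)CC1` gives 292 nM. Compound 2 `O=C1C2CCCN2C(=O)N1CN1CCN(c2ccc(F)cc2)CC1` differs from it by 4-fluorophenyl in place of 3-chlorophenyl on an amine nitrogen in a ring. In this assay compound 2 reaches only > 1000 nM, which is a limit of the measurement and not a number. The relevant bound is the limit of > 1000 nM in this assay, at which 1 of the 3 values shown sits. The measured step is an at least 3.4-fold higher number from compound 1 to compound 2 (0.53 log units; beyond the scatter), a weakening of binding that clears the scatter.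

Compound 3 `O=C1C2CCCCN2C(=O)N1CCN1CCN(c2cccc(Cl)c2)CC1` is built on a different core from compound 1; the difference between the two cores is not broken down here. In this assay compound 3 gives 375 nM. Set beside compound 1, this value lies within the scatter, so no order between compound 1 and compound 3 is drawn.

Compound 4 `O=C1C2CCCCN2C(=O)N1CCN1CCN(c2ccc(F)cc2)CC1` is not yet measured. It differs from compound 3 by 4-fluorophenyl in place of 3-chlorophenyl on an amine nitrogen in a ring, and the place of the change is the same, word for word, as in the change from compound 1 to compound 2, so this is the same change made on the second core. The step from compound 3 to compound 4 is expected to be a 4.0-fold higher number from compound 3 to compound 4 (0.60 log units; beyond the scatter), an expectation resting on the measured step of an at least 3.4-fold higher number from compound 1 to compound 2 (0.53 log units; beyond the scatter) on the first core. For compound 4 in this assay the estimated value is 1500 nM, expected to fall between 600 nM and 4000 nM, with a real chance that only a limit is returned.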

Compound 4, inhibition constant: > 1000 nM
Compound 4: no number, only a limit; the forecaster's own chance of this, stated with the estimate: 60%; the middle value is on the limit's open side.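

As far as these compounds go, on the core of compound 3, 4-fluorophenyl in place of 3-chlorophenyl gives an at least 2.6-fold higher number from compound 3 to compound 4 (0.42 log units; beyond the scatter) in this assay, so the weakening seen on the core of compound 1 appears on the second core as well, in the same direction and beyond the scatter on both: the same change on two cores in this assay, an at least 3.4-fold higher number (0.53 log units; beyond the scatter) from compound 1 to compound 2 and an at least 2.6-fold higher number (0.42 log units; beyond the scatter) from compound 3 to compound 4; the limit leaves it open whether they differ Compound 2 and compound 4 each return only a limit of the assay and not a number: the limit of > 1000 nM in this assay, at which 2 of the 4 values shown sit. The exchange therefore carries across these two cores as a direction only; its size on either core remains unknown, no statement can be made that one core is more sensitive to it than the other, and a single pair of cores does not establish a rule for the series.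

The compounds shown do not separate the identity of the halogen from its place on the aryl ring: a 4-chlorophenyl or a 3-fluorophenyl on the same ring amine would do so. Also open, from the compounds shown here alone, is how the exchange reads with a longer chain joining the core to the ring amine, as the two cores here differ in more than one place.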